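Compound 3 to compound 4: a 4-cyanophenyl swap

The source may report more compounds than this note shows. Statements on the series, on what has been measured and on what is new or still open speak of the compounds shown alone.

In a functional assay on HepG2 cells (Homo sapiens) for cytotoxicity, read by MTT assay, with a stated time of 72 h (on this read-out higher numbers stand for weaker inhibition and lower numbers for stronger inhibition), compound 1 (`CNC(=O)c1cc(Oc2ccc(C(=O)/C=C/c3cccc(Br)c3)cc2)ccn1`) gives 2870 nM and compound 3 (`CNC(=O)c1cc(Oc2ccc(C(=O)/C=C/c3ccc(F)cc3Cl)cc2)ccn1`) gives 7320 nM, the higher of these two numbers. Compound 2 (`CNC(=O)c1cc(Oc2ccc(C(=O)/C=C/c3ccc(Br)cc3)cc2)ccn1`) gives > 50000 nM, which is a limit of the assay. Compound 4 (`CNC(=O)c1cc(Oc2ccc(C(=O)/C=C/c3ccc(C#N)cc3)cc2)ccn1`) differs from compound 3 as follows: 4-cyanophenyl in place of 2-chloro-4-fluorophenyl on a double-bonded chain carbon bound to a double-bonded chain carbon. Its 4-cyanophenyl finds its nearest match in the 4-bromophenyl of compound 2, and two large steps involve that group: an at least 17-fold higher number from compound 1 to compound 2 (1.24 log units; beyond the scatter), and an at least 6.8-fold lower number from compound 2 to compound 3 (0.83 log units; beyond the scatter). The smaller 2.6-fold higher number from compound 1 to compound 3 (0.41 log units; beyond the scatter) shows that a number near compound 3 remains possible. A modest rise is therefore expected, with a 2.5-fold higher number from compound 3 to compound 4 (0.39 log units; beyond the scatter) as the expected step. Compound 4 is estimated at 18000 nM, within an expected range of 5000 nM to 50000 nM.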

Compound 4, half-maximal inhibitory concentration: 5430 nM
The estimate for compound 4 lay 3.3-fold (0.52 log units) above the measured number; low and high end bracket the measured number.
By their numbers in this assay, from the lowest: compounds 1, 4 and 3 (each within the scatter of the next, the first and the last beyond it). At a limit, above all of these: compound 2.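

At this place, 4-cyanophenyl does not follow 4-bromophenyl: an at least 9.2-fold lower number from compound 2 to compound 4 (0.96 log units; beyond the scatter). The number for compound 2 is a limit of the assay, so that step has no upper bound: the limit of > 50000 nM in this assay, at which 1 of the 4 values shown sits. In this assay, 4-cyanophenyl instead stays within the scatter of both 2-chloro-4-fluorophenyl and 3-bromophenyl, with a 1.3-fold lower number from compound 3 to compound 4 (0.13 log units; within the scatter) and a 1.9-fold higher number from compound 1 to compound 4 (0.28 log units; within the scatter), so the outlying result for 4-bromophenyl is tied to bromo rather than to any group at that ring position.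

Still open, from the compounds shown here alone, is whether an amine or a carboxylic acid on this ring would stay in the same range. A 3-cyanophenyl would test whether cyano tolerates the ring position held by bromo in compound 1.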